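The compounds below may be only part of what the source reports. "The series", "measured", "known", "first", "only" and "open" are said of these compounds alone.

Three compounds have been run in a functional assay on HEK293 cells for agonist activity at probable G-protein coupled receptor 27 (Homo sapiens), read by a luciferase reporter and beta-arrestin recruitment, with a stated time of 10 min; on this read-out lower numbers stand for an effect already at smaller amounts and higher numbers for an effect only at larger amounts of compound. Among the measured compounds shown here, compound 2 `O=C(Nc1ccc(S(=O)(=O)Nc2ccccc2)cc1)c1ccc(Cl)cc1F` gives 3980 nM, the only actual number in the set. Compound 1 `O=C(Nc1ccc(Cl)cc1Cl)c1ccc(S(=O)(=O)Nc2ccccc2)cc1` reaches only a limit of the assay, > 100000 nM. Compound 3 `O=S(=O)(Nc1ccccc1)c1ccc(NS(=O)(=O)c2ccc(Cl)cc2Cl)cc1` likewise stops at a limit, > 100000 nM. For the measured compounds named here, these two shared limits are summed up by the limit of > 100000 nM in this assay, at which 2 of the 3 values shown sit, so no measured step joins any pair here.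

Compound 4 `O=C(Nc1ccc(S(=O)(=O)Nc2ccccc2)cc1)c1ccc(Cl)cc1Cl` is compound 2 with chloro in place of fluoro on an aromatic carbon. Going by the values given here, with no measured step of this kind to lean on, the change is expected to stay within the usual scatter, in no clear direction, so compound 4 is estimated at 4000 nM (likely range 1000 nM to 16000 nM), a step of a 1.0-fold higher number from compound 2 to compound 4 (0.00 log units; within the scatter) that is expected to be small.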

Compound 4, half-maximal effective concentration: 457 nM
The estimate for compound 4 lay 8.8-fold (0.94 log units) above the measured number, and the stated range ends above it.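

In this assay, this position turns out to respond to the exchange of a single atom: going from 4-chloro-2-fluorophenyl to 2,4-dichlorophenyl, with chloro in place of fluoro, gives an 8.7-fold lower number from compound 2 to compound 4 (0.94 log units; beyond the scatter). This first measured step in the set shows that a change of one heavy atom, ortho to a large group, can move the number beyond the scatter. The other compounds add no second step to set beside it: the limit of > 100000 nM in this assay, at which 2 of the 4 values shown sit.

Going by these compounds, how a bromo, methyl or methoxy group would read at this position stays open. The compounds shown also cannot say why chloro and fluoro differ here.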